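This account rests on a few compounds, and the source may have more. Where it says the series, first, only, none or still open, it means among the compounds named here.

Measured in a functional assay on CCRF-CEM cells (Homo sapiens), read by MTT assay, with a stated time of 72 h; a higher number here means a weaker inhibitor, a lower number a stronger inhibitor:
- compound 1 `CSc1ncnc2c1c(-c1ccoc1)cn2[C@@H]1O[C@H](CO)[C@@H](O)[C@H]1O`: 14200 nM
- compound 2 `CSc1ncnc2c1c(-c1ccsc1)cn2[C@@H]1O[C@H](CO)[C@@H](O)[C@H]1O`: > 20000 nM
- compound 3 `Nc1nc(N)c2c(-c3ccco3)cn([C@@H]3O[C@H](CO)[C@@H](O)[C@H]3O)c2n1`: > 20000 nM

Compound 3 gives > 20000 nM, which is a limit of the assay and not a number. It therefore sits at the limit of > 20000 nM in this assay, at which 2 of the 3 values shown sit. Compound 2 gives > 20000 nM, which is likewise a limit.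

The compound still to be measured is compound 4 `Nc1nc(N)c2c(-c3cccs3)cn([C@@H]3O[C@H](CO)[C@@H](O)[C@H]3O)c2n1`, which carries thiophen-2-yl in place of furan-2-yl on an aromatic carbon of the shared core: thiophen-2-yl in place of furan-2-yl on an aromatic carbon.

For the measured compounds named here, only one measured step bears on this change. It is the related exchange of furan-3-yl for thiophen-3-yl on the core of compound 1, and it shows an at least 1.4-fold higher number from compound 1 to compound 2 (0.14 log units; that floor lies within the scatter). This step gives only a floor, and it comes from a different core, so its support is thin. No step beyond the scatter is therefore expected in this assay. Compound 4 is expected to stay close to the limit, and a report of only a limit is the likelier outcome.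

For compound 4 the estimated value is 18000 nM, with an expected range from 6000 nM to 30000 nM. The estimated change is an at least 1.1-fold lower number from compound 3 to compound 4 (0.04 log units; that floor lies within the scatter).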

Compound 4, half-maximal inhibitory concentration: > 20000 nM
Compound 4: no number, only a limit; the forecaster's own chance of this, stated with the estimate: 65%; middle value at least 1.1-fold (0.04 log units) away from the limit.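

In this assay compound 4 gives > 20000 nM, which is a limit of the assay and not a number. Compound 3 gives > 20000 nM, likewise a limit. No step can be read from compound 3 to compound 4. The compounds shown leave open whether thiophen-2-yl in place of furan-2-yl on the shared core changes the number at all.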